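The source may report more compounds than this note shows. Statements on the series, on what has been measured and on what is new or still open speak of the compounds shown alone.

Compound 3 `CSCC[C@H](NC(=O)c1ccc(NCc2cncn2Cc2ccccc2C)cc1-c1ccccc1)C(=O)O` stands at a limit in a functional assay on NIH3T3 cells (Mus musculus); on this read-out lower numbers stand for an effect already at smaller amounts and higher numbers for an effect only at larger amounts of compound: compound 3 gives > 10 uM, which is a limit of the assay and not a number. Its two neighbours in the series do the same. Compound 1 `CSCC[C@H](NC(=O)c1ccc(NCc2cncn2Cc2cccc(Cl)c2)cc1-c1ccccc1)C(=O)O` gives > 10 uM in this assay, again a limit. Compound 2 `CSCC[C@H](NC(=O)c1ccc(NCc2cncn2Cc2ccc([N+](=O)[O-])cc2)cc1-c1ccccc1)C(=O)O` gives > 10 uM, also a limit. Compound 3 therefore stands level with everything measured so far: the limit of > 10 uM in this assay, at which 3 of the 3 values shown sit.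

Compound 4 `CSCC[C@H](NC(=O)c1ccc(NCc2cncn2Cc2ccc(Cl)cc2)cc1-c1ccccc1)C(=O)O` differs from compound 3 by 4-chlorophenyl in place of 2-methylphenyl on a saturated chain carbon bound to an aromatic nitrogen. The measured steps at this position are a step that the two limits leave unreadable from compound 1 to compound 3, a step that the two limits leave unreadable from compound 2 to compound 3 and a step that the two limits leave unreadable from compound 1 to compound 2; none of them has a readable size, so they set no direction for the new change and show only that no variation at this position has yet brought a compound inside the measurable window. The estimated step that the limit leaves unreadable from compound 3 to compound 4 is therefore taken as small, expected to leave compound 4 at or near the limit. Compound 4 is estimated at 20 uM, with a range from 8 uM to 60 uM, and a high chance that only a limit is reported once more.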

Compound 4, concentration for half-maximal effect: > 10 uM
Compound 4: a limit, no number; the forecaster's own chance of this, stated with the estimate: 85%; the middle value does not contradict the limit.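

Compound 4 gives > 10 uM in this assay, which is a limit and not a number, so its steps from compound 1, compound 2 and compound 3 cannot be read. The compounds shown leave open how far the substituted benzyl group on the aromatic nitrogen affects this read-out, since all sit at one mark: the limit of > 10 uM in this assay, at which 4 of the 4 values shown sit.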